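The compounds below may be only part of what the source reports. "The series", "measured", "known", "first", "only" and "open" are said of these compounds alone.

The three measured compounds share one core and differ only in the group attached to the amine nitrogen in a ring. Compound 1 `NC(=O)c1c(NC(=O)c2ccccc2F)sc2c1CCN(Cc1ccc(Cl)cc1Cl)C2` gives 9610 nM in a functional assay on MKN-74 cells (Homo sapiens) for antiproliferative activity, with a stated time of 24 h; a lower number here means a stronger inhibitor, a higher number a weaker inhibitor. Compound 2 `NC(=O)c1c(NC(=O)c2ccccc2F)sc2c1CCN(C(=S)Nc1ccccc1Cl)C2` gives 11100 nM in this assay, and compound 3 `NC(=O)c1c(NC(=O)c2ccccc2F)sc2c1CCN(C(=O)Nc1ccccc1Cl)C2` gives 49600 nM. Among these three numbers compound 2 stands second highest: the step of a 1.2-fold higher number from compound 1 to compound 2 (0.06 log units; within the scatter) lies within the scatter, while the steps of a 4.5-fold higher number from compound 2 to compound 3 (0.65 log units; beyond the scatter) and a 5.2-fold higher number from compound 1 to compound 3 (0.71 log units; beyond the scatter) go beyond it.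

Compound 4 `Cc1ccc(C(=O)Nc2sc3c(c2C(N)=O)CCN(C(=S)Nc2ccccc2Cl)C3)cc1` has not yet been measured. It differs from compound 2 at a different place: 4-methylphenyl in place of 2-fluorophenyl on a carbonyl carbon. For the measured compounds named here, none of the measured steps touches that part of the molecule; every one of them changes the group on the amine nitrogen in a ring, so no measured step bears directly on this change. With nothing pointing in either direction, the step of a 1.1-fold higher number from compound 2 to compound 4 (0.03 log units; within the scatter) is expected to stay within the scatter. Compound 4 is therefore estimated at 12000 nM in this assay, within a range from 4000 nM to 40000 nM.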

Compound 4, half-maximal inhibitory concentration: 11300 nM
Estimate against measurement, compound 4: 1.1-fold (0.03 log units) above; low and high end bracket the measured number.
By their numbers in this assay, from the lowest: compounds 1, 2 and 4 (each within the scatter of the next); then compound 3.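

For the compounds shown here, until this result, every measured step changed the group on the amine nitrogen in a ring, so nothing showed how much the group on a carbonyl carbon matters. Here, 4-methylphenyl in place of 2-fluorophenyl gives a 1.0-fold higher number from compound 2 to compound 4 (0.01 log units; within the scatter) in this assay and so shows no difference beyond the scatter, although the fluorine is gone and a methyl group has entered. With this nitrogen group in place, the two groups on the carbonyl carbon cannot be told apart, whereas a change on the nitrogen gave a 4.5-fold higher number from compound 2 to compound 3 (0.65 log units; beyond the scatter) in the same test.

Open, on these data alone, is whether an amine, a carboxylic acid or a longer chain on the phenyl ring would shift the number, and whether the same swap reads alike with the 2,4-dichlorobenzyl group of compound 1. No measurement shown here offers an explanation for this result.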